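Replacing Sec-Butyl with 4-Aminobutyl on Compound 1

This account rests on a few compounds, and the source may have more. Where it says the series, first, only, none or still open, it means among the compounds named here.

Compound 1 `CC[C@H](C)[C@H](NC(=O)CN(c1nc(Cl)nc2[nH]cnc12)C1CC1)C(=O)O` gives 30.3% in a functional assay on the whole organism (Tail, strain ICR) with Mus musculus as the target, in the tail flick test, with a stated time of 30 min, at a dose of 25 umol/kg by the oral route (a lower number here means a weaker effect, a higher number a stronger effect of the compound at the dose given), the lowest of the three numbers shown, although compound 2 `O=C(OCc1ccccc1)[C@@H]1CCCN1C(=O)CN(c1nc(Cl)nc2[nH]cnc12)C1CC1`, which gives 33.2%, lies within the scatter of it. Compound 3 `CC[C@H](C)[C@H](NC(=O)CN(c1nc(Cl)nc2[nH]cnc12)C1CC1)C(=O)OCc1ccccc1` gives 41.4%. Within the data shown here, the only single-point step known, a number 11.1 percentage points higher from compound 1 to compound 3 (beyond the scatter), concerns benzyl in place of hydrogen on an oxygen next to a carbonyl group and does not touch the saturated chain carbon bound to an amide-type nitrogen and a carbonyl carbon. Compound 4 `NCCCC[C@H](NC(=O)CN(c1nc(Cl)nc2[nH]cnc12)C1CC1)C(=O)O` differs from compound 1 exactly there: 4-aminobutyl in place of sec-butyl on a saturated chain carbon bound to an amide-type nitrogen and a carbonyl carbon. Among the measured compounds shown here, no measured step bears on this change, so no shift beyond the scatter is expected. Compound 4 is therefore estimated at 30%, within 15% to 45%. The expected step is a number 0.3 percentage points lower from compound 1 to compound 4 (within the scatter).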

Compound 4, a percentage reported as activity, at one dose (the size of the read-out at that dose, not a potency): 31.2%
The estimate for compound 4 lay 1.2 percentage points below the measured number; low and high end bracket the measured number.
By their numbers in this assay, from the lowest: compounds 1, 4, 2 and 3 (each within the scatter of the next, the first and the last beyond it).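

In this assay, 4-aminobutyl in place of sec-butyl gives a number 0.9 percentage points higher from compound 1 to compound 4 (within the scatter), so on a saturated chain carbon bound to an amide-type nitrogen and a carbonyl carbon, the read-out at this dose does not separate the two chains. The nitrogen of 4-aminobutyl and the loss of the sec-butyl stereocentre thus leave no mark beyond the scatter. No available evidence explains this outcome.

On these data alone, it remains open whether benzyl on the acid oxygen of compound 4 would raise the number as it does for compound 3. Equally open, as far as these compounds go, is how a shorter amine chain or a carboxylic acid at the chain end would read here.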